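Aryl group swap on the carbonyl: compound 2 to compound 3

This account rests on a few compounds, and the source may have more. Where it says the series, first, only, none or still open, it means among the compounds named here.

Measured in a functional assay on MDA-MB-231 cells (Homo sapiens) for antiproliferative activity, read by MTT assay, with a stated time of 72 h; a higher number here means a weaker inhibitor, a lower number a stronger inhibitor:
- compound 1 `CC1=CC[C@H]2[C@H](CC[C@]2(C)O)C(C)(C)[C@@H]1CC[C@H]1[C@]2(C)CC[C@H](OC(=O)c3ccccc3)C(C)(C)O[C@H]2CC[C@@]1(C)O`: 16100 nM
- compound 2 `CC1=CC[C@H]2[C@H](CC[C@]2(C)O)C(C)(C)[C@@H]1CC[C@H]1[C@]2(C)CC[C@H](OC(=O)c3cccc([N+](=O)[O-])c3)C(C)(C)O[C@H]2CC[C@@]1(C)O`: 34700 nM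

Compound 2, at 34700 nM, holds the higher of the two numbers. Compound 3 `CC1=CC[C@H]2[C@H](CC[C@]2(C)O)C(C)(C)[C@@H]1CC[C@H]1[C@]2(C)CC[C@H](OC(=O)c3ccccc3C(F)(F)F)C(C)(C)O[C@H]2CC[C@@]1(C)O` is not yet measured. The change is 2-(trifluoromethyl)phenyl in place of 3-nitrophenyl on a carbonyl carbon. Within the data shown here, the only measured step that bears on it is a 2.2-fold higher number from compound 1 to compound 2 (0.33 log units; beyond the scatter), a modest one with nitro in place of hydrogen. Among the measured compounds shown here, no measured step covers the trifluoromethyl group, so the expectation is loose: a modest step toward a lower number in this assay, similar in size to that step reversed. The expected step is a 2.0-fold lower number from compound 2 to compound 3 (0.31 log units; beyond the scatter). The estimate for compound 3 is 17000 nM, with an expected range of 8000 nM to 36000 nM.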

Compound 3, half-maximal inhibitory concentration: 31500 nM
Estimate against measurement, compound 3: 1.9-fold (0.27 log units) below, within the range that was stated.
By their numbers in this assay, from the lowest: compounds 1, 3 and 2 (each within the scatter of the next, the first and the last beyond it).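

In this assay, 2-(trifluoromethyl)phenyl in place of 3-nitrophenyl on the carbonyl carbon leaves the two compounds within the scatter (a 1.1-fold lower number from compound 2 to compound 3 (0.04 log units; within the scatter)). Trifluoromethyl in place of hydrogen also stays within the scatter (a 2.0-fold higher number from compound 1 to compound 3 (0.29 log units; within the scatter)), unlike the nitro step (a 2.2-fold higher number from compound 1 to compound 2 (0.33 log units; beyond the scatter)), so only that step is resolved so far. Nothing measured here accounts for this result.

This swap changes the substituent and its ring place together, so neither can be read alone. Open too, from the compounds shown here alone, is whether an amine or a carboxylic acid on the aryl ring would move the value beyond the scatter.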